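This account rests on a few compounds, and the source may have more. Where it says the series, first, only, none or still open, it means among the compounds named here.

Measured compounds:
- compound 1 `CC(C)(C(=O)Nc1ccc(C(=O)Nc2ccc(F)cc2N)cc1)c1ccccc1`: 0% in an assay on isolated protein for inhibition of histone deacetylase 5 (Homo sapiens), tested at 1 uM; on this read-out lower numbers stand for less inhibition and higher numbers for more inhibition at the one concentration tested (going by the name of the read-out)
- compound 2 `CC(C)[C@@H](C(=O)Nc1ccc(C(=O)Nc2ccccc2N)cc1)c1ccccc1`: 9% in this assay

Compound 1 gives the smaller of the two numbers, but the gap to compound 2 lies within the usual scatter of repeated measurements, so the two compounds cannot be told apart on these data: both sit at the bottom of the read-out in this assay.

The unmeasured compound 3 `CC(C)(C(=O)Nc1ccc(C(=O)Nc2ccccc2N)cc1)c1ccccc1` is obtained from compound 1 by one change: hydrogen in place of fluoro on an aromatic carbon. For the measured compounds named here, no step between two measured compounds with this same difference is available here, so its effect has not been seen directly.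

With both measured compounds close to zero in this assay, compound 3 is expected to stay in the same region, and the expected step of a number 3 percentage points higher from compound 1 to compound 3 (within the scatter) is small, with no direction beyond the scatter. Compound 3 is therefore estimated at 3%, within a range from -5% to 12%.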

Compound 3, a percentage reported as inhibition, at one concentration (the size of the read-out at that concentration, not a potency): 0%
Estimate against measurement, compound 3: 3 percentage points above, within the range that was stated.
By their numbers in this assay, from the lowest: compounds 1, 3 and 2 (each within the scatter of the next).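

In this assay, hydrogen in place of fluoro on the aromatic carbon meta to an amino group and para to a large group gives no change at the digits printed from compound 1 to compound 3 (within the scatter). For the compounds shown here, this is the first direct reading at this position: going from 2-amino-4-fluorophenyl to 2-aminophenyl does not lift the compound off the bottom of the read-out at the one concentration tested. The starting point of this step is low, and the step shows only that fluoro is not what holds compound 1 there. No measurement shown offers an explanation for the result.

Going by these compounds, it remains open whether a larger group at this carbon, such as methoxy or a thiophene ring, would give a different reading. On these data alone, it also remains open whether fluoro would matter on a compound with clear inhibition.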